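Pyridin-3-yl to pyridin-4-yl at the Assay Limit

The source may hold more compounds than are shown below. What is called first, only, known or untested is meant among the compounds shown, and "the series" means these compounds.

In a functional assay on HeLa cells (Homo sapiens) for cytotoxicity, read by WST assay, with a stated time of 48 h (a higher number here means a weaker inhibitor, a lower number a stronger inhibitor), compound 1 `O[C@@H](c1ccccc1)[C@H]1CO[C@H](c2ccccc2)[C@@H](C/C=C/c2cccc(F)c2)C1` gives 8380 nM and compound 2 `Cc1ccc(/C=C/C[C@H]2C[C@@H]([C@@H](O)c3ccccc3)CO[C@@H]2c2ccccc2)cc1C` gives 10000 nM. The step between them is a 1.2-fold higher number from compound 1 to compound 2 (0.08 log units; within the scatter). Compound 3 `O[C@@H](c1ccccc1)[C@H]1CO[C@H](c2ccccc2)[C@@H](C/C=C/c2cccnc2)C1` reads > 100000 nM, which is a limit of the assay and not a number. It stands as the weakest of the three, with an at least 11-fold higher number from compound 1 to compound 3 (1.07 log units; beyond the scatter) and an at least 10-fold higher number from compound 2 to compound 3 (1.00 log units; beyond the scatter).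

Compound 4 `O[C@@H](c1ccccc1)[C@H]1CO[C@H](c2ccccc2)[C@@H](C/C=C/c2ccncc2)C1` changes compound 3 in one place: pyridin-4-yl in place of pyridin-3-yl on a double-bonded chain carbon bound to a double-bonded chain carbon. The change sits on a double-bonded chain carbon bound to a double-bonded chain carbon, where the measured steps also fall. None of those steps compares two pyridine rings, so the evidence is indirect. Compound 4 keeps a pyridine ring, and both steps into pyridin-3-yl were large. For the measured compounds named here, compound 3, the only measured compound with such a ring, holds the limit of > 100000 nM. No step beyond the scatter is therefore expected in this assay, and a second limit is quite possible. The estimated change is an at least 1.2-fold lower number from compound 3 to compound 4 (0.09 log units; that floor lies within the scatter). Compound 4 is expected near 80000 nM, within an estimated range of 25000 nM to 100000 nM.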

Compound 4, half-maximal inhibitory concentration: > 100000 nM
Compound 4 gave a limit, no number (the forecaster's own chance of this, stated with the estimate: 55%); at least 1.2-fold (0.09 log units) between middle value and limit.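

Until now, only pyridin-3-yl had carried a very weak reading at this position. Pyridin-4-yl on the same double-bonded chain carbon does so too in this assay, with an at least 10-fold higher number from compound 2 to compound 4 (1.00 log units; beyond the scatter) and an at least 11-fold higher number from compound 1 to compound 4 (1.07 log units; beyond the scatter). Thus both pyridine compounds sit apart from the 3-fluorophenyl and 3,4-dimethylphenyl compounds, and no compound shown goes against this, but neither pyridine compound gives a number, only a limit of the assay, so the step from compound 3 to compound 4 cannot be read and the two rings cannot be ranked: the limit of > 100000 nM in this assay, at which 2 of the 4 values shown sit.

As far as these compounds go, how far past that limit either compound lies remains open. Also open, from the compounds shown here alone, is whether pyridin-2-yl, an aminophenyl or a carboxyphenyl group in the same place would give a number or reach the limit as well.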